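The source may report more compounds than this note shows. Statements on the series, on what has been measured and on what is new or still open speak of the compounds shown alone.

Compound 1 `C#CC(C)OC(=O)c1ccc(C(CC)(CC)c2ccc(OCC(=O)C(C)(C)C)c(C)c2)n1CC`: 210 nM
Compound 2 `CCOC(=O)CC(C)OC(=O)c1ccc(C(CC)(CC)c2ccc(OCC(=O)C(C)(C)C)c(C)c2)n1CC`: > 50000 nM

In an assay on HL-60 cells for agonist activity at vitamin D3 receptor (Homo sapiens), read by microscopy, with a stated time of 96 h (a higher number here means that more compound is needed for the effect, a lower number that less compound is needed), compound 1 gives 210 nM. Compound 2 gives only a limit, > 50000 nM, not a number; it sits at the limit of > 50000 nM in this assay, at which 1 of the 2 values shown sits, the weak end of what is shown. Compound 3 `CCn1c(C(=O)OCc2ccccn2)ccc1C(CC)(CC)c1ccc(OCC(=O)C(C)(C)C)c(C)c1` differs from compound 2 by (pyridin-2-yl)methyl in place of 1-((ethoxycarbonyl)methyl)ethyl on an oxygen next to a carbonyl group. Within the data shown here, one measured step touches this oxygen: an at least 230-fold higher number from compound 1 to compound 2 (2.37 log units; beyond the scatter), a large move, so the group on the oxygen next to the carbonyl decides the read-out here. Compound 3 is expected at 600 nM, range 100 nM to 10000 nM, because an at least 230-fold higher number from compound 1 to compound 2 (2.37 log units; beyond the scatter) shows how strongly this position answers. The expected step is an at least 83-fold lower number from compound 2 to compound 3 (1.92 log units; beyond the scatter).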

Compound 3, half-maximal effective concentration: > 50000 nM
Compound 3 ended at the assay's limit; the forecaster's own chance of this, stated with the estimate: 20%; at least 83-fold (1.92 log units) between middle value and limit.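

A second, quite different group on the oxygen next to a carbonyl group, (pyridin-2-yl)methyl with its aromatic ring, also loses the read-out in this assay, with an at least 230-fold higher number from compound 1 to compound 3 (2.37 log units; beyond the scatter). Among the three compounds, only compound 1, with 1-methylprop-2-yn-1-yl, gives a number, and the two replacements both end at a limit: the limit of > 50000 nM in this assay, at which 2 of the 3 values shown sit. The step from compound 2 to compound 3 cannot be read, as both values are limits.

Still open, going by these compounds, is whether the ethynyl or the methyl branch of compound 1 matters. A plain 1-methylethyl group or a longer alkynyl chain on this oxygen would separate the two.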